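The compounds below may be only part of what the source reports. "The series", "measured", "known", "first", "only" and "open" are said of these compounds alone.

Working notes on the series. In a functional assay on KB cells (Homo sapiens) for antiproliferative activity, read by MTT assay, with a stated time of 72 h (a lower number here means a stronger inhibitor, a higher number a weaker inhibitor), compound 1 `COc1ccc(-c2c(-c3cc(OC)c(OC)c(OC)c3)ssc2=O)cc1[N+](=O)[O-]` gives > 100000 nM, which is a limit of the assay and not a number. Compound 2 `COc1ccc(-c2c(-c3cc(OC)c(OC)c(OC)c3)ss/c2=N/O)cc1` gives > 100000 nM, which is also a limit. Compound 2 therefore has no numerical position, and both readings so far sit at the same point: the limit of > 100000 nM in this assay, at which 2 of the 2 values shown sit.

Compound 3 `COc1ccc(-c2c(-c3cc(OC)c(OC)c(OC)c3)ss/c2=N/O)cc1[N+](=O)[O-]` carries nitro in place of hydrogen on an aromatic carbon of compound 2, ortho to a methoxy group and meta to a large group: nitro in place of hydrogen on an aromatic carbon. Among the measured compounds shown here, no measured step in this assay shows what such a change does, so no shift beyond the scatter is expected, and a further limit reading is the likeliest outcome. The expected change is an at least 1.2-fold lower number from compound 2 to compound 3 (0.09 log units; that floor lies within the scatter). For compound 3 the estimated value is 80000 nM, within an expected range of 20000 nM to 150000 nM.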

Compound 3, half-maximal inhibitory concentration: 5260 nM
The estimate for compound 3 lay 15-fold (1.18 log units) above the measured number; measured number below the stated range.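

Among the compounds shown here, on the ring that carries the methoxy group, nitro in place of hydrogen on an aromatic carbon, ortho to that methoxy group, gives the only numerical reading so far in this assay, with an at least 19-fold lower number from compound 2 to compound 3 (1.27 log units; beyond the scatter). That step is a floor and not a full size, since compound 2 is only a limit, and the limit remains the commonest reading: the limit of > 100000 nM in this assay, at which 2 of the 3 values shown sit. Compound 1 also carries the nitro group, with a carbonyl where compound 3 has the oxime, and compound 1 gives > 100000 nM and that is a limit, so within these compounds nitro gives a numerical reading only together with the oxime.

Going by these compounds, whether another group at this place, such as an amine or a nitrile, would give a reading like that of compound 3 stays open. So does the effect of a methyl ether in place of the oxime.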